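Isobutyl ether in place of the cyanobenzyl ether

A few compounds are considered here, and "the series" means these few. Any claim that something is new, unique, unknown or untested is made for them only; others in the source may bear on it.

Measured so far:
compound 1 `Cc1nn(-c2ncnc3nc[nH]c23)c2c1C(OCc1ccc(C#N)cc1)CC(=O)N2`: 4 nM
compound 2 `C=CCN1c2c(n(C)c(=O)n(C)c2=O)NC1N/N=C/c1ccc(O)cc1O`: 340 nM

In a functional assay on HEK293 cells for agonist activity at G-protein coupled receptor 39 (Homo sapiens), read by scintillation proximity assay and inositol phosphate accumulation, with a stated time of 75 min, in the presence of a further agent that is not named here (a higher number here means that more compound is needed for the effect, a lower number that less compound is needed), compound 1 gives 4 nM, the lowest of the two numbers; compound 2 gives 340 nM, a higher number beyond the scatter, so compound 1 stands as the more potent of the pair. Compound 3 `Cc1nn(-c2ncnc3nc[nH]c23)c2c1C(OCC(C)C)CC(=O)N2` has not been measured. It differs from compound 1 in one place: isopropyl in place of 4-cyanophenyl on a saturated chain carbon bound to an oxygen on a saturated carbon. Within the data shown here, no step between measured compounds covers a change of this kind, so the expectation rests on compound 1 alone. The step of a 7.5-fold higher number from compound 1 to compound 3 (0.88 log units; beyond the scatter) is expected to go toward a higher number, beyond the scatter. Compound 3 is therefore estimated at 30 nM, within 6 nM to 200 nM.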

Compound 3, half-maximal effective concentration: 4 nM
For compound 3 the middle estimate is 7.5-fold (0.88 log units) above the measured one; the whole stated range lies above it.
By their numbers in this assay, from the lowest: compounds 1 and 3 (each within the scatter of the next); then compound 2.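

In this assay the exchange reads no change at the digits printed from compound 1 to compound 3 (within the scatter), so at this place on the ether the 4-cyanophenyl, with its aromatic ring and nitrile, is not needed to hold the number: isopropyl, a smaller group without a ring, serves equally in this assay. The ether side chain therefore accepts both an aromatic and a branched saturated end group. Nothing on hand bears on why the two groups read alike. Open, as far as these compounds go, is how a longer chain, an amine or a carboxylic acid in place of isopropyl would read.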